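Swapping the chain end of compound 3

A few compounds are considered here, and "the series" means these few. Any claim that something is new, unique, unknown or untested is made for them only; others in the source may bear on it.

Compound 1 `Nc1nc(-c2ccccn2)nn1-c1ncnc2ccccc12` gives 9000 nM
Compound 2 `COc1cc2ncnc(-n3cnc(-c4ccccn4)n3)c2cc1OC` gives 30000 nM
Compound 3 `COc1cc2ncnc(-n3nc(-c4ccccn4)nc3N)c2cc1OCCCN(C)C` gives 53000 nM

In a physicochemical assay for solubility, in phosphate buffer, with a stated time of 18 h, at pH 7.4 (on this read-out higher numbers stand for higher solubility and lower numbers for lower solubility), compound 3 gives 53000 nM and stands within the scatter of compound 2 at 30000 nM while compound 1 at 9000 nM lies clearly lower than compound 3. The next compound is compound 4 `COc1cc2ncnc(-n3nc(-c4ccccn4)nc3N)c2cc1OCCCCNC(=O)OC(C)(C)C` and the change is ((tert-butoxycarbonyl)amino)methyl in place of dimethylamino on a saturated chain carbon, three bonds along the chain from an oxygen on an aromatic ring with ((tert-butoxycarbonyl)amino)methyl in place of dimethylamino on a saturated chain carbon, three bonds along the chain from an oxygen on an aromatic ring. For the measured compounds named here, no two measured compounds differ in one place only, so nothing measures this change directly. A drop beyond the scatter is expected, and the estimated step is an 8.8-fold lower number from compound 3 to compound 4 (0.95 log units; beyond the scatter) on this measure. That expectation is a judgement from the structural change, with compound 1 at 9000 nM as the nearest guide among the measured numbers. Compound 4 is estimated at 6000 nM with an expected range of 1500 nM to 25000 nM in this assay for this measurement.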

Compound 4, solubility: 500 nM
The estimate for compound 4 lay 12-fold (1.08 log units) above the measured number; measured number outside the range, below it.
By their numbers in this assay, from the lowest: compound 4; then compound 1; then compounds 2 and 3 (each within the scatter of the next).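

In this assay, compound 3 and compound 4 are the only pair shown that differ in one place, so the chain end can now be read directly. Putting ((tert-butoxycarbonyl)amino)methyl in place of dimethylamino on a saturated chain carbon, three bonds along the chain from an oxygen on an aromatic ring, comes with a 110-fold lower number from compound 3 to compound 4 (2.03 log units; beyond the scatter), a large step with the rest of the structure unchanged. Nothing available here accounts for the size of this step.

Going by these compounds, the change alters several things at once: the 3-(dimethylamino)propyl chain becomes 4-((tert-butoxycarbonyl)amino)butyl, and the dimethylamino end gives way to a carbamate-bearing one, so which part goes with the step stays open. A free amine, as in 4-aminobutyl, or a carboxylic acid at the same chain end could begin to separate these parts.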